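A few compounds are considered here, and "the series" means these few. Any claim that something is new, unique, unknown or untested is made for them only; others in the source may bear on it.

Measured compounds:
- compound 1, `CC1(C)CCC(C)(C)c2c1cc(O)c(C(=O)c1ccc3cc(C(=O)O)ccc3c1)c2F`: 87%
- compound 2, `CC1(C)CCC(C)(C)c2cc(C(=O)c3ccc4cc(C(=O)O)ccc4c3)c(O)cc21`: 76%
- compound 3, `Cc1cc2c(cc1C(=O)c1ccc3cc(C(=O)O)ccc3c1)C(C)(C)CCC2(C)C`: 81%

All three were tested in an assay on isolated protein with retinoic acid receptor beta (Homo sapiens) as the target; a lower number here means a smaller maximal response, a higher number a larger maximal response. Compound 3 stands second highest of the three numbers, but its distance to compound 2 and its distance to compound 1 are both within the usual scatter, so no order among them can be claimed.

Compound 4, `CC1(C)CCC(C)(C)c2cc(C(=O)c3ccc4cc(C(=O)O)ccc4c3)c(F)cc21`, has not yet been measured. It differs from compound 3 in one place: fluoro in place of methyl on an aromatic carbon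

Among the compounds with values here, no measured step swaps these two groups directly. The closest guide is the step of a number 11 percentage points lower from compound 1 to compound 2 (beyond the scatter), where the fluoro group was removed and the maximal response fell by a modest amount; a fluoro group entering might therefore be expected to move the number up, if at all. The step of a number 5 percentage points higher from compound 2 to compound 3 (within the scatter), which put a methyl group in, stayed within the scatter. On this basis the expected change a number 4 percentage points higher from compound 3 to compound 4 (within the scatter) is small, upward at most, and likely within the scatter.

Compound 4 is therefore estimated to give about 85%, with a range from 72% to 98%.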

Compound 4, largest response reached (reported as maximum), in percent of the reference or control that the assay uses: 81%
Beside the measured number, compound 4's estimate is 4 percentage points above it; low and high end bracket the measured number.
By their numbers in this assay, from the lowest: compounds 2, 3, 4 and 1 (each within the scatter of the next, the first and the last beyond it).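

In this assay, the aromatic carbon ortho to a large group has now carried three different groups, and fluoro in place of methyl gives no change at the digits printed from compound 3 to compound 4 (within the scatter) in this read-out. Fluoro in place of hydroxy gives a number 5 percentage points higher from compound 2 to compound 4 (within the scatter) and also stays within the scatter. Until now, only the change from hydroxy to methyl had been seen here; with fluoro added, the hydroxy, methyl and fluoro versions of this core cannot be told apart by maximal response.

No evidence is available to explain why these three groups give such similar numbers. From the compounds shown here alone, whether this similarity would extend to chloro, methoxy or an amine at the same carbon remains open, as does whether it would hold in a different kind of assay.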